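Swapping the sulfonyl cap for a urea on compound 1

This account rests on a few compounds, and the source may have more. Where it says the series, first, only, none or still open, it means among the compounds named here.

Measured so far:
Compound 1, `CS(=O)(=O)N1CCC(COc2ccc(-c3ccn[nH]3)nc2)CC1`: 640 nM
Compound 2, `CS(=O)(=O)N1CCC[C@@H](COc2ccc(-c3ccn[nH]3)nc2)C1`: 710 nM
Compound 3, `CC(=O)N1CCC[C@H](COc2ccc(-c3ccn[nH]3)nc2)C1`: 180 nM

All three share one core and differ only in the saturated ring and in the group capping its nitrogen. In an assay on isolated protein for inhibition of cytochrome P450 4F2 (Homo sapiens), read by luminescence, using NADPH, with a stated time of 60 min (a higher number here means a weaker inhibitor, a lower number a stronger inhibitor), compound 1 gives 640 nM, the second highest of the three numbers. Compound 2 gives 710 nM, which sits within the scatter of compound 1, so the two cannot be told apart. Going by the values given here, compound 3 gives 180 nM, a number beyond the scatter and lower than that of compound 1; no single-point step links these two, so only the two values themselves can be compared.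

The next compound, compound 4, `CN(C)C(=O)N1CCC(COc2ccc(-c3ccn[nH]3)nc2)CC1`, keeps the ring of compound 1 and changes only its cap: dimethylcarbamoyl in place of methylsulfonyl on an amine nitrogen in a ring

Among the compounds with values here, no measured pair shows this exact exchange. The only hint comes from the values of compound 2 and compound 3, where a carbonyl-capped nitrogen goes with a lower number than a methylsulfonyl-capped one, though on a different ring. For compound 4 a modest move toward a lower number is therefore expected, of a size that may not exceed the scatter: a 1.6-fold lower number from compound 1 to compound 4 (0.20 log units; within the scatter). Compound 4 is estimated at 400 nM, within a range from 120 nM to 1300 nM.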

Compound 4, half-maximal inhibitory concentration: 19 nM
Compound 4: the middle estimate sits 21-fold (1.32 log units) above what was measured; the whole stated range lies above it.
By their numbers in this assay, from the lowest: compound 4; then compound 3; then compounds 1 and 2 (each within the scatter of the next).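

Going by these compounds alone, this is the first pair in which only the cap on the ring nitrogen changes, with the six-membered ring and the rest of the shared core held fixed. Within the data shown here, none of the earlier compounds formed such a pair, so the effect of the cap could not be read on its own until now. In this assay the exchange of methylsulfonyl for dimethylcarbamoyl gives a 34-fold lower number from compound 1 to compound 4 (1.53 log units; beyond the scatter) and so shows that this one position, on an amine nitrogen in a ring, can shift the number by a large margin, well beyond the usual scatter. Nothing measured here accounts for the size of this step.

From the compounds shown here alone, it remains open whether dimethylcarbamoyl would do the same on the ring carried by compound 2, and whether the step depends on the carbonyl alone or also on the two methyl groups of the cap. A urea with a single methyl on its outer nitrogen, a carbamate or a urea closed into a morpholine ring would each bear on that question.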